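A hydroxy for chloro swap on a non-toxic scaffold

This account rests on a few compounds, and the source may have more. Where it says the series, first, only, none or still open, it means among the compounds named here.

Compound 1 `O=c1cc(CNCc2cccc(F)c2)oc2ccc(O)c(O)c12` carries a 3-fluorophenyl on the saturated chain carbon bound to the amine nitrogen. In an ADME assay on Huh-7 cells (Homo sapiens) for cytotoxicity (on this read-out lower numbers stand for higher toxicity in this test and higher numbers for lower toxicity in this test), compound 1 gives only a limit of > 100000 nM. Compound 2 `O=c1cc(CNCc2ccc(Cl)cc2)oc2ccc(O)c(O)c12` carries a 4-chlorophenyl in that place. In this assay compound 2 likewise gives only a limit of > 100000 nM. The step that the two limits leave unreadable from compound 1 to compound 2 therefore cannot be read, and compound 2 stands at the limit of > 100000 nM in this assay, at which 2 of the 2 values shown sit. Compound 3 `O=c1cc(CNCc2ccc(O)cc2)oc2ccc(O)c(O)c12` differs from compound 2 by hydroxy in place of chloro on an aromatic carbon. Going by the values given here, the single measured step bears on this change only in that neither of its ends was a number, so no direction and no size can be taken from it. With nothing readable to push it either way, compound 3 is expected to remain at the limit as well, an expected step that the limit leaves unreadable from compound 2 to compound 3. Compound 3 is estimated at 150000 nM, within 50000 nM to 500000 nM.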

Compound 3, half-maximal cytotoxic concentration: 62700 nM
For compound 3 the middle estimate is 2.4-fold (0.38 log units) above the measured one; low and high end bracket the measured number.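

Going by these compounds alone, of the three compounds, only compound 3 gives a number rather than a limit in this assay, so this position on the aromatic carbon, para to a large group, is the first place where a change can be given a direction. Hydroxy in place of chloro reads as an at least 1.5-fold lower number from compound 2 to compound 3 (0.20 log units; that floor lies within the scatter), and the wider swap of 3-fluorophenyl for 4-hydroxyphenyl reads as an at least 1.5-fold lower number from compound 1 to compound 3 (0.20 log units; that floor lies within the scatter). Each of these is only a floor with a limit at one end, so the true size of both steps stays unread: the limit of > 100000 nM in this assay, at which 2 of the 3 values shown sit.

The compounds shown leave open whether another group on that aromatic carbon, such as an amine or a carboxylic acid, would also give a number. They also leave open whether a longer chain at the amine nitrogen would change the read-out with the 4-hydroxyphenyl kept.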